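One more chloro group on a series held at its limit

The source may hold more compounds than are shown below. What is called first, only, known or untested is meant among the compounds shown, and "the series" means these compounds.

Of the compounds shown here, three sharing one core have been measured in a functional assay on Raji cells (Homo sapiens) for cytotoxicity, with a stated time of 72 h (on this read-out higher numbers stand for an effect only at larger amounts of compound and lower numbers for an effect already at smaller amounts), and none of them has yet given a number. Compound 1 `C=C[C@@](C)(/C=C/c1ccc(OCc2ccccc2)cc1)CCC=C(C)C` reads > 26000 nM as a limit of the assay. Compound 2 `C=C[C@@](C)(/C=C/c1ccc(Nc2ccc(F)c(F)c2)cc1)CCC=C(C)C` reads > 26000 nM as a limit as well. Compound 3 `C=C[C@@](C)(/C=C/c1ccc(Nc2ccc(Cl)cc2)cc1)CCC=C(C)C` also reads > 26000 nM as a limit and has no number of its own. The whole picture so far is the limit of > 26000 nM in this assay, at which 3 of the 3 values shown sit, and nothing more.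

Compound 4 `C=C[C@@](C)(/C=C/c1ccc(Nc2ccc(Cl)c(Cl)c2)cc1)CCC=C(C)C` comes from compound 3 by one change: chloro in place of hydrogen on an aromatic carbon and so (4-chlorophenyl)amino becomes (3,4-dichlorophenyl)amino. The closest measured comparison is a step that the two limits leave unreadable from compound 2 to compound 3 where 4-chlorophenyl takes the place of 3,4-difluorophenyl on the nitrogen. The swaps away from benzyloxy, a step that the two limits leave unreadable from compound 1 to compound 2 and a step that the two limits leave unreadable from compound 1 to compound 3 in turn, are no more telling. No size can be carried over from these steps, so the expectation rests on the limit of compound 3 at > 26000 nM alone.

The expected step in this assay is a step that the limit leaves unreadable from compound 3 to compound 4 with no direction that these data can support. Another limit is the likeliest report. For compound 4 the estimate is 30000 nM with an expected range from 10000 nM to 60000 nM in this read-out.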

Compound 4, half-maximal effective concentration: > 26000 nM
Compound 4: a limit, no number; the forecaster's own chance of this, stated with the estimate: 75%; the middle value does not contradict the limit.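

In this assay compound 4 gives > 26000 nM as a limit and not a number. For the compounds shown here, its steps from compound 1, compound 2 and compound 3 cannot be read, so this result adds no new step. The compounds shown leave open whether any of these changes alters the effect on the cells, and in which direction.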